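The source may report more compounds than this note shows. Statements on the series, on what has been measured and on what is new or still open speak of the compounds shown alone.

Compound 1 `Nc1n[nH]c2cccc(-c3cccc(NC(=O)Nc4cccc(F)c4)c3)c12` gives 1240 nM
Compound 2 `COc1cccc(NC(=O)Nc2cccc(-c3cccc4[nH]nc(N)c34)c2)c1` gives 2860 nM

In a functional assay on SMMC-7721 cells (Homo sapiens) for inhibition, read by MTT assay, with a stated time of 48 h (a higher number here means a weaker inhibitor, a lower number a stronger inhibitor), compound 2 stands highest of the two at 2860 nM and is the weaker inhibitor of the pair. Compound 3 `Nc1n[nH]c2cccc(-c3cccc(NC(=O)Nc4cccc(C(F)(F)F)c4)c3)c12` differs from it by one group trifluoromethyl in place of methoxy on an aromatic carbon with trifluoromethyl in place of methoxy on an aromatic carbon. Among the compounds with values here, one measured step bears on this, the modest 2.3-fold higher number from compound 1 to compound 2 (0.36 log units; beyond the scatter) with methoxy in place of fluoro. Within the data shown here, with compound 1 at 1240 nM as the only guide, a modest step to a lower number is expected. The expected step is a 2.0-fold lower number from compound 2 to compound 3 (0.31 log units; beyond the scatter) by this estimate. For compound 3 the estimated value is 1400 nM with an expected range from 550 nM to 3500 nM in this assay.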

Compound 3, half-maximal inhibitory concentration: 1410 nM
Compound 3: middle estimate off by 1.0-fold (0.00 log units), on the low side; measured number inside the range.
By their numbers in this assay, from the lowest: compounds 1 and 3 (each within the scatter of the next); then compound 2.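

In this assay trifluoromethyl in place of methoxy, on an aromatic carbon meta to a large group, gives a gain (a 2.0-fold lower number from compound 2 to compound 3 (0.31 log units; beyond the scatter)), so the loss seen with methoxy does not extend to every replacement of fluoro at this position. Trifluoromethyl in place of fluoro gives no readable change (a 1.1-fold higher number from compound 1 to compound 3 (0.06 log units; within the scatter)), which leaves methoxy as the only one of the three groups that stands apart. Nothing at hand accounts for this difference.

As far as these compounds go, whether an amine, a carboxylic acid or a longer chain at this position would keep the number of compound 1 or compound 3 stays open. So does whether the same order of groups holds in other cells.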